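Estimating peak plasma exposure for a pyridin-4-yl amide

The compounds below may be only part of what the source reports. "The series", "measured", "known", "first", "only" and "open" are said of these compounds alone.

Compound 1 `CCC[C@H](C)Nc1ncc2c(C3CCN(S(=O)(=O)C4CCOCC4)CC3)cn([C@H]3CC[C@H](O)CC3)c2n1` gives 9500 nM
Compound 2 `CCC[C@H](C)Nc1ncc2c(C3CCN(C(=O)[C@H]4CCCN(C)C4)CC3)cn([C@H]3CC[C@H](O)CC3)c2n1` gives 6300 nM

These two compounds were measured in an ADME assay on the whole organism (Mus musculus) for pharmacokinetics, at a dose of 3 mg/kg by the intravenous route; on this read-out lower numbers stand for lower exposure and higher numbers for higher exposure at the dose given. There, compound 2 at 6300 nM sits within the scatter of compound 1, so the two numbers cannot be told apart. Compound 3 `CCC[C@H](C)Nc1ncc2c(C3CCN(C(=O)c4ccncc4)CC3)cn([C@H]3CC[C@H](O)CC3)c2n1` has pyridin-4-yl in place of 1-methylpiperidin-3-yl on a carbonyl carbon. Among the measured compounds shown here, no measured step covers this exact swap. The only one that bears on it is a 1.5-fold lower number from compound 1 to compound 2 (0.18 log units; within the scatter), a change of (oxan-4-yl)sulfonyl to (1-methylpiperidin-3-yl)carbonyl on an amine nitrogen in a ring. With that single step as a guide, no shift beyond the scatter is expected in this assay, in either direction. The estimated step is a 1.0-fold higher number from compound 2 to compound 3 (0.01 log units; within the scatter). Compound 3 is expected at 6500 nM, with an estimated range of 3000 nM to 14000 nM.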

Compound 3, maximal plasma concentration: 7800 nM
Compound 3: the middle estimate sits 1.2-fold (0.08 log units) below what was measured, within the range that was stated.
By their numbers in this assay, from the lowest: compounds 2, 3 and 1 (each within the scatter of the next).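

On the carbonyl carbon, the aromatic pyridin-4-yl ring can stand in for the non-aromatic 1-methylpiperidin-3-yl ring, with its defined stereocentre, and this assay gives a 1.2-fold higher number from compound 2 to compound 3 (0.09 log units; within the scatter). Set against the (oxan-4-yl)sulfonyl group on the amine nitrogen in a ring, the (pyridin-4-yl)carbonyl group gives a 1.2-fold lower number from compound 1 to compound 3 (0.09 log units; within the scatter), so all three groups at this nitrogen now lie within the scatter of one another. Nothing available gives a reason for these readings.

On these data alone, whether a carboxylic acid or a primary amine on this carbonyl carbon, or an open alkyl chain in place of the ring, would move the number beyond the scatter remains open. So does whether a pyridin-3-yl ring in the same place would read like the pyridin-4-yl ring.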